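The source may report more compounds than this note shows. Statements on the series, on what has been measured and on what is new or still open speak of the compounds shown alone.

Going by the values given here, compound 1 `Cc1cc(C)c(NC(=O)N(Cc2ccc(-c3ccnn3C)cc2)C2CCCCCC2)c(C)c1` and compound 2 `Cc1cc(C)c(NC(=O)N(Cc2ccc(-c3cnn(C)c3)cc2)C2CCCCCC2)c(C)c1` are the two measured members. In a functional assay on a cell-free system (plasma) with sterol O-acyltransferase, Soat (Rattus norvegicus) as the target (a higher number here means that more compound is needed for the effect, a lower number that less compound is needed), compound 1 gives only a limit, < 1 mg/kg. In this assay compound 2 gives 0.31 mg/kg. Among the compounds with values here, compound 2 therefore stands as the only compound with a read number; the other value shown is a limit.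

Within the data shown here, the single measured step, a step that the limit leaves unreadable from compound 1 to compound 2, cannot be sized because the limit of < 1 mg/kg in this assay, at which 1 of the 2 values shown sits, leaves it unreadable. It also concerns a different exchange than the one now in question.

Compound 3 `Cc1cc(C)c(NC(=O)N(Cc2ccc(-n3ccnc3)cc2)C2CCCCCC2)c(C)c1` differs from compound 2 in one place: 1H-imidazol-1-yl in place of 1-methyl-1H-pyrazol-4-yl on an aromatic carbon. Among the measured compounds shown here, no measured step bears on this exchange, so the expectation rests on compound 2 alone, and the writer expects no step beyond the scatter, a 1.3-fold higher number from compound 2 to compound 3 (0.11 log units; within the scatter), in either direction.

Compound 3 is accordingly estimated at 0.4 mg/kg, with a range from 0.15 mg/kg to 1.2 mg/kg.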

Compound 3, dose for half-maximal effect: > 1 mg/kg
Compound 3: no number, only a limit; the forecaster's own chance of this, stated with the estimate: 15%; middle value at least 2.5-fold (0.39 log units) from the limit.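

Exchanging the 1-methyl-1H-pyrazol-4-yl group for 1H-imidazol-1-yl, para to a large group, gives an at least 3.2-fold higher number from compound 2 to compound 3 (0.50 log units; beyond the scatter) in this assay, so this position responds to the choice of five-membered aromatic ring, even though the two groups have the same counts of hetero atoms, donors and acceptors. Compound 3 gives only a limit, > 1 mg/kg, and not a number. The other step, a number no lower from compound 1 to compound 3 (the limit leaves the size open), cannot be read for size, because both compounds stand at limits: the limit of < 1 mg/kg in this assay, at which 1 of the 3 values shown sits.

On these data alone, whether a 1H-pyrazol-1-yl group, an amine or a carboxylic acid at this place would hold the number of compound 2 remains open. Also open is what causes the step, since the values shown give no reason for it.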